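Swapping the amide aryl group on a quinoline core

A few compounds are considered here, and "the series" means these few. Any claim that something is new, unique, unknown or untested is made for them only; others in the source may bear on it.

Compound 2 `CCN1CCN(c2cc(C)c3cc(NC(=O)c4ccccc4Cl)ccc3n2)CC1` carries a 2-chlorophenyl group on the amide carbonyl carbon of the shared core. In a functional assay on SK-BR-3 cells (Homo sapiens) for antiproliferative activity, read by MTT assay, with a stated time of 72 h (a higher number here means a weaker inhibitor, a lower number a stronger inhibitor), compound 2 reaches only the upper limit of the measurement, reported as > 50000 nM. Among the measured compounds shown here, its neighbour compound 1 `CCN1CCN(c2cc(C)c3cc(NC(=O)c4cccnc4)ccc3n2)CC1` holds a pyridin-3-yl group at the same position and in this assay compound 1 gives 10600 nM; the step of an at least 4.7-fold higher number from compound 1 to compound 2 (0.67 log units; beyond the scatter) shows that exchanging this aryl group can move the read-out well beyond the scatter, although only one value of the pair is a true number (the limit of > 50000 nM in this assay, at which 1 of the 2 values shown sits). Compound 3 `CCN1CCN(c2cc(C)c3cc(NC(=O)c4cc5ccccc5[nH]4)ccc3n2)CC1` now replaces the 2-chlorophenyl group: 1H-indol-2-yl in place of 2-chlorophenyl on a carbonyl carbon. For the measured compounds named here, no measured step covers 1H-indol-2-yl at this position, so the direction is open; compound 3 is expected to give 30000 nM, between 5000 nM and 100000 nM, an expected step of an at least 1.6-fold lower number from compound 2 to compound 3 (0.22 log units; that floor lies within the scatter).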

Compound 3, half-maximal inhibitory concentration: 2550 nM
For compound 3 the middle estimate is 12-fold (1.07 log units) above the measured one, and the stated range ends above it.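

In this assay, the 1H-indol-2-yl group gives the lowest number of the three, with a 4.2-fold lower number from compound 1 to compound 3 (0.62 log units; beyond the scatter) and an at least 19-fold lower number from compound 2 to compound 3 (1.29 log units; beyond the scatter). Only the first of these steps joins two true numbers, while the second rests on a limit for compound 2: the limit of > 50000 nM in this assay, at which 1 of the 3 values shown sits. Changing the group on this carbonyl carbon can therefore lower the number as well as raise it, and compared with 2-chlorophenyl the entering group brings a five-membered aromatic ring and a hydrogen-bond donor.

The compounds shown do not separate the contribution of that donor from that of the second ring. They also leave open how a benzofuran-2-yl group, or a 1H-indol-2-yl group with a methyl on its ring nitrogen, would behave at this position.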